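A few compounds are considered here, and "the series" means these few. Any claim that something is new, unique, unknown or untested is made for them only; others in the source may bear on it.

Compound 1, `CCCCc1nc(C(C)C)c(CC(=O)OCCC)c(=O)n1Cc1ccc(-c2ccccc2-c2noc(=O)[nH]2)cc1`, is a compound whose fate in liver tissue is tested in an ADME assay on microsomes from liver (Homo sapiens) for metabolic stability, with a stated time of 30 min; a lower number here means that less of the compound is left, a higher number that more of the compound is left. In this assay compound 1 gives 7.2%. Within the data shown here, its only measured neighbour is compound 2, `CCCCc1nc(C(C)C)c(CC(=O)OCC(C)C)c(=O)n1Cc1ccc(-c2ccccc2-c2noc(=O)[nH]2)cc1`, which in this assay gives 8.8%; the step is a number 1.6 percentage points higher from compound 1 to compound 2 (within the scatter), so the two numbers lie within the usual scatter of one another and neither can be called more stable than the other.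

Compound 3, `CCCCc1nc(C(C)C)c(CC(=O)OC(CC)CC)c(=O)n1Cc1ccc(-c2ccccc2-c2noc(=O)[nH]2)cc1`, has not yet been measured. It differs from compound 1 by ethyl in place of hydrogen on a saturated chain carbon bound to an oxygen next to a carbonyl group and a saturated chain carbon. Among the measured compounds shown here, the one measured step that resembles it is the change from compound 1 to compound 2, which also added a small carbon group to the ester's alkyl chain and moved the read-out by a number 1.6 percentage points higher from compound 1 to compound 2 (within the scatter), within the scatter. On that single precedent, no step beyond the scatter is expected for compound 3 in this assay, in either direction.

The expected step for compound 3 is therefore a number 1.8 percentage points higher from compound 1 to compound 3 (within the scatter). Compound 3 is estimated at 9%, with a range from 3% to 18%.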

Compound 3, percent of the compound remaining: 7.7%
Compound 3: the middle estimate sits 1.3 percentage points above what was measured, within the range that was stated.
By their numbers in this assay, from the lowest: compounds 1, 3 and 2 (each within the scatter of the next).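

In this assay, the new result extends the picture from a methyl added further along the ester's alkyl chain to branching on the saturated chain carbon bound to the ester oxygen: exchanging propyl for pentan-3-yl gives a number 0.5 percentage points higher from compound 1 to compound 3 (within the scatter) and still stays within the scatter, and the comparison with the isobutyl ester gives the same kind of answer (a number 1.1 percentage points lower from compound 2 to compound 3 (within the scatter)). The three esters shown, carrying propyl, isobutyl and pentan-3-yl on the oxygen, therefore cannot be told apart in this read-out, and adding ethyl at this carbon does not separate compound 3 from either of the others. Nothing available bears on what lies behind this agreement.

The compounds shown leave open whether an ester with a larger or differently shaped group on the oxygen, such as a tert-butyl or a benzyl group, would give a number outside the scatter. They also leave open what an amide or a carboxylic acid at this place, in place of the ester, would give.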